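The source may report more compounds than this note shows. Statements on the series, on what has been measured and on what is new or still open speak of the compounds shown alone.

Measured in a functional assay on MCF7 cells (Homo sapiens) for antiproliferative activity, read by sulforhodamine B assay, with a stated time of 48 h; a lower number here means a stronger inhibitor, a higher number a weaker inhibitor:
- compound 1 `Cc1ccccc1OS(=O)(=O)c1ccc(N2CCN(C)C2=O)cc1`: 5600 nM
- compound 2 `CCc1ccccc1OS(=O)(=O)c1ccc(N2CCN(C)C2=O)cc1`: 26000 nM
- compound 3 `CCCN1CCN(c2ccc(S(=O)(=O)Oc3ccccc3C)cc2)C1=O`: > 100000 nM, a limit of the assay and not a number

Compound 3 stands at the limit of > 100000 nM in this assay, at which 1 of the 3 values shown sits. This gives a limit rather than a number as the starting point, so the next step can only be judged loosely.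

Compound 4 `CCCN1CCN(c2ccc(S(=O)(=O)Oc3ccccc3CC)cc2)C1=O` differs from compound 3 by methyl in place of hydrogen on a saturated chain carbon bound to an aromatic carbon. The same difference reads as 2-methylphenyl to 2-ethylphenyl.

This exact change has been measured once, in going to compound 2: a 4.6-fold higher number from compound 1 to compound 2 (0.67 log units; beyond the scatter). That is a modest step toward the weaker side. The other measured step, an at least 17-fold higher number from compound 1 to compound 3 (1.25 log units; beyond the scatter), is large, but it concerns a different place in the molecule. It sets where the starting compound stands and does not size the present change.

With a single precedent, a modest step toward a higher number is expected in this assay, and the assay will probably report only a limit again. The estimated step is a step that the limit leaves unreadable from compound 3 to compound 4. Compound 4 is estimated at 150000 nM, with an expected range of 60000 nM to 500000 nM.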

Compound 4, half-maximal inhibitory concentration: 2300 nM
For compound 4 the middle estimate is 65-fold (1.81 log units) above the measured one; the whole stated range lies above it.
By their numbers in this assay, from the lowest: compound 4; then compound 1; then compound 2. At a limit, above all of these: compound 3.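

In this assay, methyl in place of hydrogen on a saturated chain carbon bound to an aromatic carbon gives an at least 43-fold lower number from compound 3 to compound 4 (1.63 log units; beyond the scatter), so the 2-methylphenyl to 2-ethylphenyl change has no single direction across the two cores: the same change on two cores in this assay, a 4.6-fold higher number (0.67 log units; beyond the scatter) from compound 1 to compound 2 and an at least 43-fold lower number (1.63 log units; beyond the scatter) from compound 3 to compound 4, at least 200-fold (2.30 log units) apart, beyond the scatter of two such steps

Compound 3 stands at > 100000 nM, which is a limit of the assay and not a number.

The change on the saturated chain carbon bound to an amide-type nitrogen in a ring also behaves differently once the 2-ethylphenyl group is present, giving an 11-fold lower number from compound 2 to compound 4 (1.05 log units; beyond the scatter), so the effect of each change depends on the group at the other place: the same change on two cores in this assay, an at least 17-fold higher number (1.25 log units; beyond the scatter) from compound 1 to compound 3 and an 11-fold lower number (1.05 log units; beyond the scatter) from compound 2 to compound 4, at least 200-fold (2.30 log units) apart, beyond the scatter of two such steps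

These four compounds form a single set of paired changes, and they leave open whether this dependence extends beyond methyl, ethyl and the two groups compared here. A butyl chain in place of the ethyl on the phenyl group, or a longer chain or an amine on the amide-type nitrogen, would show whether the lower value of compound 4 at 2300 nM belongs to this one pairing or to a wider trend.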